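The source may report more compounds than this note shows. Statements on the series, on what has been measured and on what is new or still open speak of the compounds shown alone.

Compound 1 `COc1ccc(-c2ccnc(C(=O)Nc3ccc(Oc4ccnc5cc(OCCCN6CCCCC6)c(OC)cc45)c(F)c3)c2)cc1` and compound 2 `COc1ccc(-c2ccnc(C(=O)Nc3ccc(Oc4ccnc5cc(OCCCN6CCN(C)CC6)c(OC)cc45)c(F)c3)c2)cc1` share one core and were both tested in a functional assay on NCI-H460 cells (Homo sapiens) for cytotoxicity, read by MTT assay, with a stated time of 72 h; a lower number here means a stronger inhibitor, a higher number a weaker inhibitor. In this assay compound 1 gives 200 nM, and compound 2 gives 370 nM. The change between them is 4-methylpiperazin-1-yl in place of piperidin-1-yl on a saturated chain carbon, three bonds along the chain from an oxygen on an aromatic ring, and it produced a 1.9-fold higher number from compound 1 to compound 2 (0.27 log units; within the scatter).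

Compound 3 `COc1cc2c(Oc3ccc(NC(=O)c4nccc(-c5ccc(C)cc5)n4)cc3F)ccnc2cc1OCCCN1CCCCC1` is built on a different core; the difference between the two cores is not broken down here. In this assay compound 3 gives 230 nM, which sits close to the value of compound 1 and also close to that of compound 2.

Compound 4 `COc1cc2c(Oc3ccc(NC(=O)c4nccc(-c5ccc(C)cc5)n4)cc3F)ccnc2cc1OCCCN1CCN(C)CC1` has not yet been measured. Within the data shown here, it differs from compound 3 by 4-methylpiperazin-1-yl in place of piperidin-1-yl on a saturated chain carbon, three bonds along the chain from an oxygen on an aromatic ring, which is the same change as the one from compound 1 to compound 2, made at the same place in the chain.

Among the measured compounds shown here, since the only earlier example of this change is the step from compound 1 to compound 2, a similar small step, a 1.9-fold higher number from compound 3 to compound 4 (0.27 log units; within the scatter), is expected here as well. In this assay compound 4 is therefore estimated at 430 nM, with a likely range from 200 nM to 950 nM.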

Compound 4, half-maximal inhibitory concentration: 160 nM
For compound 4 the middle estimate is 2.7-fold (0.43 log units) above the measured one; the measured number lies below the stated range.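

In this assay, putting 4-methylpiperazin-1-yl in place of piperidin-1-yl on the core of compound 3 gives a 1.4-fold lower number from compound 3 to compound 4 (0.16 log units; within the scatter). Set beside the earlier example of the same change, the two cores cannot be told apart: the same change on two cores in this assay, a 1.9-fold higher number (0.27 log units; within the scatter) from compound 1 to compound 2 and a 1.4-fold lower number (0.16 log units; within the scatter) from compound 3 to compound 4, 2.7-fold (0.42 log units) apart, within the scatter of two such steps. In these two pairs, then, the change can be carried from one core to the other without a step that stands clear of the scatter, but two small steps cannot show whether the two cores truly respond alike, nor which way the change moves the number on either core, if it moves it at all.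

The compounds shown leave open whether a different ring at the end of the chain, such as morpholin-4-yl, or an open-chain amine such as dimethylamino, would also give values in this range. They also leave open whether a shorter link, as in 2-(piperidin-1-yl)ethyl, would leave the number as undisturbed.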